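This account rests on a few compounds, and the source may have more. Where it says the series, first, only, none or still open, it means among the compounds named here.

Working notes on the aryl hydrazone series.

The shared core of compound 1 `CN(C)CCn1cnnc1-c1cc(Oc2ccc(NC(=O)N/N=C/c3c(Cl)cccc3Cl)cc2F)ccn1` carries a 2,6-dichlorophenyl on the carbon with a double bond to nitrogen; in a functional assay on NCI-H460 cells (Homo sapiens) for cytotoxicity, read by MTT assay, with a stated time of 72 h (on this read-out lower numbers stand for stronger inhibition and higher numbers for weaker inhibition), compound 1 gives 350 nM. Compound 2 `CN(C)CCn1cnnc1-c1cc(Oc2ccc(NC(=O)N/N=C/c3ccc(F)cc3)cc2F)ccn1` gives 1980 nM in this assay, and compound 3 `COc1cc(/C=N/NC(=O)Nc2ccc(Oc3ccnc(-c4nncn4CCN(C)C)c3)c(F)c2)cc(OC)c1OC` gives 2770 nM. Compound 3 stands at the highest of the three numbers; its nearest neighbour is compound 2 and its furthest is compound 1. The steps run a 5.7-fold higher number from compound 1 to compound 2 (0.75 log units; beyond the scatter), a 7.9-fold higher number from compound 1 to compound 3 (0.90 log units; beyond the scatter) and a 1.4-fold higher number from compound 2 to compound 3 (0.15 log units; within the scatter).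

Compound 4 `CN(C)CCn1cnnc1-c1cc(Oc2ccc(NC(=O)N/N=C/c3ccc(O)c(O)c3)cc2F)ccn1` differs from compound 3 in one place: 3,4-dihydroxyphenyl in place of 3,4,5-trimethoxyphenyl on a carbon with a double bond to nitrogen. Among the measured compounds shown here, no measured step exchanges a hydroxyl-bearing aryl group. The step that bears most directly on this change is the exchange of one aryl group for another on the same carbon while the rest stays fixed, a 1.4-fold higher number from compound 2 to compound 3 (0.15 log units; within the scatter), which stayed within the scatter; the two dichlorophenyl steps were larger, but both started from compound 1 rather than from compound 3.

On that basis the expectation for compound 4 in this assay is a step of a 1.1-fold lower number from compound 3 to compound 4 (0.04 log units; within the scatter), not beyond the scatter in either direction. Compound 4 is therefore estimated at 2500 nM in this assay, with a range of 800 nM to 8000 nM.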

Compound 4, half-maximal inhibitory concentration: 1930 nM
Estimate against measurement, compound 4: 1.3-fold (0.11 log units) above; the range from low to high includes it.
By their numbers in this assay, from the lowest: compound 1; then compounds 4, 2 and 3 (each within the scatter of the next).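

In this assay, a hydroxyl-bearing aryl group now appears on the carbon with a double bond to nitrogen, and the result is a 1.4-fold lower number from compound 3 to compound 4 (0.16 log units; within the scatter). Against the 4-fluorophenyl of compound 2 the result is a 1.0-fold lower number from compound 2 to compound 4 (0.01 log units; within the scatter), so 3,4-dihydroxyphenyl, 3,4,5-trimethoxyphenyl and 4-fluorophenyl cannot be told apart at this position, although the entering group has 2 hydrogen-bond donors and the leaving group has 0. Compound 1 stays apart from all three others, with a 5.5-fold higher number from compound 1 to compound 4 (0.74 log units; beyond the scatter), which leaves 2,6-dichlorophenyl as the only one of the four aryl groups separated beyond the scatter, and no measurement at hand bears on the reason for this.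

The compounds shown leave open whether a 2-chlorophenyl or a 2,6-dimethylphenyl group would fall with compound 1 or with the other three. Also open, going by these compounds, is what a cyclohexyl group, or a phenyl ring carrying an amine or a carboxylic acid, would give on this carbon.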